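The source may hold more compounds than are shown below. What is called first, only, known or untested is meant among the compounds shown, and "the series" means these compounds.

In a functional assay on UACC-62 cells (Homo sapiens) for inhibition, read by sulforhodamine B assay, with a stated time of 48 h (on this read-out higher numbers stand for weaker inhibition of growth and lower numbers for stronger inhibition of growth), compound 1 (`CC1(/C=C/c2ccc(C(F)(F)F)cc2)C=CC(=O)O1`) gives 15500 nM as its reading, and compound 2 (`CC1(/C=C/c2ccc(O)cc2)C=CC(=O)O1`) gives 55300 nM as the higher of the two numbers, which makes it the weaker growth inhibitor of this pair. Compound 3 (`COc1ccc(/C=C/C2(C)C=CC(=O)O2)cc1`) follows from compound 2 through methyl in place of hydrogen on an oxygen on an aromatic ring in the form of methyl in place of hydrogen on an oxygen on an aromatic ring, hydroxy to methoxy. Within the data shown here, one measured step bears on this change: a 3.6-fold higher number from compound 1 to compound 2 (0.55 log units; beyond the scatter) for hydroxy in place of trifluoromethyl on an aromatic carbon, modest and beyond the scatter. That step does not test methoxy directly, so the basis is thin. With the hydroxy gone, a small move towards the lower number of compound 1 is expected. The expected change is a 1.8-fold lower number from compound 2 to compound 3 (0.27 log units; within the scatter) in this estimate, smaller than the measured step and towards stronger inhibition. For compound 3 the estimated value is 30000 nM with an expected range from 13000 nM to 65000 nM at this stage.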

Compound 3, concentration for total growth inhibition: 147000 nM
Compound 3: the middle estimate sits 4.9-fold (0.69 log units) below what was measured, outside the stated range (above it).
By their numbers in this assay, from the lowest: compound 1; then compound 2; then compound 3.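

Methyl in place of hydrogen on the oxygen does not bring the reading towards that of compound 1: in this assay the change gives a 2.7-fold higher number from compound 2 to compound 3 (0.42 log units; beyond the scatter), towards weaker inhibition of growth. Methoxy also stands further from trifluoromethyl, with a 9.5-fold higher number from compound 1 to compound 3 (0.98 log units; beyond the scatter), than hydroxy does, with a 3.6-fold higher number from compound 1 to compound 2 (0.55 log units; beyond the scatter), so that among these three groups on the aromatic ring the order of numbers runs trifluoromethyl, hydroxy, methoxy, and capping the hydroxy adds to the loss rather than reversing it. No supporting data on these compounds offer an explanation for this rise.

Going by these compounds, whether an amine, a carboxylic acid or a longer chain such as ethoxy on the same aromatic carbon would fall within this order remains open. The compounds shown also leave open whether the order holds when the shared core is changed elsewhere.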